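The compounds below may be only part of what the source reports. "The series", "measured", "known", "first", "only" and "open" are said of these compounds alone.

Measured in a functional assay on DU-145 cells (Homo sapiens) for inhibition, read by trypan blue exclusion, with a stated time of 96 h; on this read-out higher numbers stand for weaker inhibition of growth and lower numbers for stronger inhibition of growth:
- compound 1 `Cc1cc(C)cc(/C=C(\C(=O)c2ccc(Cl)cc2)S(=O)(=O)c2ccc(Br)cc2)c1` gives 10000 nM
- compound 2 `COc1ccc(/C=C(\C(=O)c2ccc(Cl)cc2)S(=O)(=O)c2ccc(C)cc2)cc1O` gives 1000 nM
- compound 3 `Cc1ccc(S(=O)(=O)/C(=C/c2cc(C)ccc2C)C(=O)c2ccc(Cl)cc2)cc1` gives 1000 nM

Level with compound 2, compound 3 stands at 1000 nM, and the two share the lowest of the three numbers. Compound 1 gives 10000 nM. Its gap to those two is wider than the scatter.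

Compound 4 `Cc1ccc(S(=O)(=O)/C(=C/c2cc(C)cc(C)c2)C(=O)c2ccc(Cl)cc2)cc1` follows by one exchange, 3,5-dimethylphenyl in place of 2,5-dimethylphenyl (3,5-dimethylphenyl in place of 2,5-dimethylphenyl on a double-bonded chain carbon bound to a double-bonded chain carbon). Among the compounds with values here, the one measured step at this place, no change at the digits printed from compound 2 to compound 3 (within the scatter), stayed within the scatter. Compound 1 carries 3,5-dimethylphenyl at that place and gives 10000 nM, so a modest rise in the number in this assay is expected, close to the scatter. The expected step is a 2.0-fold higher number from compound 3 to compound 4 (0.30 log units; within the scatter). The estimate for compound 4 is 2000 nM, with an expected range of 700 nM to 8000 nM.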

Compound 4, concentration for 50% growth inhibition: 1000 nM
The estimate for compound 4 lay 2.0-fold (0.30 log units) above the measured number; low and high end bracket the measured number.
By their numbers in this assay, from the lowest: compounds 2, 3 and 4 (each within the scatter of the next); then compound 1.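

In this assay, 3,5-dimethylphenyl in place of 2,5-dimethylphenyl gives no change at the digits printed from compound 3 to compound 4 (within the scatter), and in place of 3-hydroxy-4-methoxyphenyl it gives no change at the digits printed from compound 2 to compound 4 (within the scatter), so these three groups on the double-bonded chain carbon read alike. The high number of compound 1 does not follow 3,5-dimethylphenyl: methyl in place of bromo on an aromatic carbon gives a 10-fold lower number from compound 1 to compound 4 (1.00 log units; beyond the scatter). No available evidence accounts for either result.

Open, from the compounds shown here alone, is whether an amine or a carboxylic acid on the aryl group at this place would stay at this level. Also open, going by these compounds, is whether bromo gives a similar step alongside 2,5-dimethylphenyl.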